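The source may report more compounds than this note shows. Statements on the series, on what has been measured and on what is new or still open speak of the compounds shown alone.

Three compounds share one core and differ only in the phenyl group carried on a nitrogen of that core. In a functional assay on MCF7 cells (Homo sapiens) for cytotoxicity, read by MTT assay, with a stated time of 72 h (on this read-out higher numbers stand for weaker inhibition and lower numbers for stronger inhibition), compound 1 `FC(F)(F)c1ccc(CSc2nc(Nc3ccccc3C(F)(F)F)c3ccccc3n2)cc1` gives > 50000 nM, which is a limit of the assay rather than a number. Compound 2 `FC(F)(F)c1ccc(CSc2nc(Nc3cccc(C(F)(F)F)c3)c3ccccc3n2)cc1` gives 15300 nM, and compound 3 `FC(F)(F)c1ccc(CSc2nc(Nc3cccc(Cl)c3)c3ccccc3n2)cc1` gives 25100 nM; these two numbers differ by a 1.6-fold higher number from compound 2 to compound 3 (0.21 log units; within the scatter), within the scatter, so compound 3 stands alongside compound 2 rather than apart from it. The two steps of an at least 3.2-fold lower number from compound 1 to compound 2 (0.51 log units; beyond the scatter) and an at least 1.9-fold lower number from compound 1 to compound 3 (0.29 log units; that floor lies within the scatter) are only floors, resting on (the limit of > 50000 nM in this assay, at which 1 of the 3 values shown sits). Compound 4 `O=[N+]([O-])c1cccc(Nc2nc(SCc3ccc(C(F)(F)F)cc3)nc3ccccc23)c1` is not yet measured; it differs from compound 3 by nitro in place of chloro on an aromatic carbon. Going by the values given here, the one measured step at that same place, a 1.6-fold higher number from compound 2 to compound 3 (0.21 log units; within the scatter), stayed within the scatter, so no step beyond the scatter is expected from this exchange either. Compound 4 is therefore estimated at 22000 nM, with a range from 8000 nM to 60000 nM. The expected step is a 1.1-fold lower number from compound 3 to compound 4 (0.06 log units; within the scatter).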

Compound 4, half-maximal inhibitory concentration: > 50000 nM
Compound 4 was reported as a limit; the forecaster's own chance of this, stated with the estimate: 25%; middle value at least 2.2-fold (0.35 log units) away from the limit.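

Going by these compounds alone, until now the one step read at this place stayed within the scatter, but nitro in place of trifluoromethyl gives the first step here that goes beyond it: an at least 3.2-fold higher number from compound 2 to compound 4 (0.51 log units; beyond the scatter). Against chloro the step is less firm, an at least 1.9-fold higher number from compound 3 to compound 4 (0.29 log units; that floor lies within the scatter), so in this assay the change from chloro to nitro can be called neither neutral nor clearly weakening, although this place on the ring is clearly not indifferent to the group it carries. The step between compound 1 and compound 4 cannot be read, because both values are limits: the limit of > 50000 nM in this assay, at which 2 of the 4 values shown sit.

Going by these compounds, the true sizes of the two readable steps remain open, as each is only a floor. Also open, on these data alone, is what an amine, a methoxy group or a nitrile would give at this same place.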